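The compounds below may be only part of what the source reports. "The series", "measured", "known", "first", "only" and "open" are said of these compounds alone.

Three compounds of the series carry numbers in a functional assay on MCF7 cells (Homo sapiens) for inhibition, read by MTT assay; on this read-out lower numbers stand for stronger inhibition of growth and higher numbers for weaker inhibition of growth. Compound 1 `COc1cc2oc(-c3cccc(NC(=O)c4ccc(Cl)cc4)c3)cc(=O)c2c(OC)c1OC` gives 8780 nM, the lowest number of the three, though its gap to compound 2 lies within the scatter. Compound 2 `COc1cc2oc(-c3cccc(NC(=O)c4ccc(C#N)cc4)c3)cc(=O)c2c(OC)c1OC` gives 12700 nM, and compound 3 `COC(=O)c1ccc(C(=O)Nc2cccc(-c3cc(=O)c4c(OC)c(OC)c(OC)cc4o3)c2)cc1` gives 30300 nM. The step of a 1.4-fold higher number from compound 1 to compound 2 (0.16 log units; within the scatter) stays within the scatter, whereas a 3.5-fold higher number from compound 1 to compound 3 (0.54 log units; beyond the scatter) and a 2.4-fold higher number from compound 2 to compound 3 (0.38 log units; beyond the scatter) are modest but beyond it. Compound 4 `COc1ccccc1C(=O)Nc1cccc(-c2cc(=O)c3c(OC)c(OC)c(OC)cc3o2)c1` is not yet measured; from compound 1 it differs by 2-methoxyphenyl in place of 4-chlorophenyl on a carbonyl carbon. Going by the values given here, the changes behind a 1.4-fold higher number from compound 1 to compound 2 (0.16 log units; within the scatter), a 3.5-fold higher number from compound 1 to compound 3 (0.54 log units; beyond the scatter) and a 2.4-fold higher number from compound 2 to compound 3 (0.38 log units; beyond the scatter) all sit on the 4-chlorophenyl group and none exceeds a modest size, so only a modest step is expected here, direction uncertain; no measured step exchanges the ring itself. The estimate for compound 4 is 12000 nM, between 5000 nM and 30000 nM, an expected 1.4-fold higher number from compound 1 to compound 4 (0.14 log units; within the scatter).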

Compound 4, concentration for 50% growth inhibition: 15300 nM
Estimate against measurement, compound 4: 1.3-fold (0.11 log units) below, and the stated range covers the measured number.
By their numbers in this assay, from the lowest: compounds 1, 2, 4 and 3 (each within the scatter of the next, the first and the last beyond it).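

Replacing the whole ring on the carbonyl carbon, not only its substituent, stays within the scatter against all three earlier compounds: a 1.7-fold higher number from compound 1 to compound 4 (0.24 log units; within the scatter), a 1.2-fold higher number from compound 2 to compound 4 (0.08 log units; within the scatter) and a 2.0-fold lower number from compound 3 to compound 4 (0.30 log units; within the scatter). Compound 4 thus lies within the scatter of both compound 1 and compound 3, although those two lie beyond the scatter of each other. No supporting data bear on the reason for this result.

All four compounds keep a six-membered aromatic ring on this carbonyl carbon. Open, from the compounds shown here alone, is whether an amine or a carboxylic acid on that ring, or a longer chain in its place, would give a step beyond the scatter.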